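Bromo for Fluoro on Two Related Thienopyrimidinone Cores

A few compounds are considered here, and "the series" means these few. Any claim that something is new, unique, unknown or untested is made for them only; others in the source may bear on it.

Compound 1 `CC(C)(C)Nc1nc2cc(-c3ccc(Br)cc3)sc2c(=O)[nH]1` and compound 2 `CC(C)(C)Nc1nc2cc(-c3ccc(F)cc3)sc2c(=O)[nH]1` share a core and differ only at one aromatic carbon. In an ADME assay on HepG2 cells (Homo sapiens) for cytotoxicity, read by MTT assay, with a stated time of 72 h (on this read-out higher numbers stand for lower toxicity in this test and lower numbers for higher toxicity in this test), compound 1 gives 1400 nM, while compound 2 gives 5100 nM. The step of a 3.6-fold lower number from compound 2 to compound 1 (0.56 log units; beyond the scatter) describes this change, (bromo in place of fluoro on an aromatic carbon).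

Compound 3 `CC(C)Nc1nc2c(-c3ccc(F)cc3)csc2c(=O)[nH]1` carries a different core; how its core differs from that of compound 2 is not broken down here. In this assay compound 3 reaches only a limit, > 15600 nM, and the limit of > 15600 nM in this assay, at which 1 of the 3 values shown sits, records that limit.

Compound 4 `CC(C)Nc1nc2c(-c3ccc(Br)cc3)csc2c(=O)[nH]1` has not been measured in this assay. It differs from compound 3 by bromo in place of fluoro on an aromatic carbon, the same change as that from compound 2 to compound 1, since the place is the same in both cases. The step of an at least 2.6-fold lower number from compound 3 to compound 4 (0.41 log units; beyond the scatter) is expected, resting on the step of a 3.6-fold lower number from compound 2 to compound 1 (0.56 log units; beyond the scatter). The starting point is uncertain: in this assay compound 3 shows only the limit > 15600 nM. Compound 4 is therefore estimated at 6000 nM in this assay, within a range from 2500 nM to 20000 nM.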

Compound 4, half-maximal cytotoxic concentration: 6500 nM
Beside the measured number, compound 4's estimate is 1.1-fold (0.03 log units) below it; low and high end bracket the measured number.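

In this assay, bromo in place of fluoro gives an at least 2.4-fold lower number from compound 3 to compound 4 (0.38 log units; beyond the scatter), so the number falls in the same direction on the core of compound 3 as on the core of compound 2. Set side by side, the two steps read: the same change on two cores in this assay, a 3.6-fold lower number (0.56 log units; beyond the scatter) from compound 2 to compound 1 and an at least 2.4-fold lower number (0.38 log units; beyond the scatter) from compound 3 to compound 4; the limit leaves it open whether they differ The direction therefore carries over between these two cores, but this single pair does not show that the size carries over, since compound 3 is held only by a limit of the assay: the limit of > 15600 nM in this assay, at which 1 of the 4 values shown sits.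

The compounds shown leave open whether a chloro or a methoxy group at the same place would fall in line with fluoro or bromo. They also leave open whether the change would run the same way on a third core, or with a carboxylic acid or a longer chain in place of the amine side chain of these compounds.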